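The source may hold more compounds than are shown below. What is called first, only, known or untested is meant among the compounds shown, and "the series" means these compounds.

In a functional assay on MDA-MB-231 cells (Homo sapiens) for antiproliferative activity, read by MTT assay, with a stated time of 24 h (a lower number here means a stronger inhibitor, a higher number a weaker inhibitor), compound 1 `O=S(=O)(c1cccnc1)N1CCN(c2nccc(Oc3cc(Cl)cc(Cl)c3)n2)CC1` gives 24800 nM. Compound 2 `O=S(=O)(c1ccc(F)cc1)N1CCN(c2nccc(Oc3cc(Cl)cc(Cl)c3)n2)CC1` reaches only a limit of the assay, > 50000 nM. Among the compounds with values here, compound 3 `Cc1ccc(NC(=O)N2CCN(c3nccc(Oc4cc(Cl)cc(Cl)c4)n3)CC2)cc1` gives 11600 nM, the lowest number of the series so far. The measured steps to it are a 2.1-fold lower number from compound 1 to compound 3 (0.33 log units; beyond the scatter) and an at least 4.3-fold lower number from compound 2 to compound 3 (0.63 log units; beyond the scatter), while an at least 2.0-fold higher number from compound 1 to compound 2 (0.30 log units; that floor lies within the scatter) is the remaining step. Compound 4 `O=C(Nc1ccc(C(F)(F)F)cc1)N1CCN(c2nccc(Oc3cc(Cl)cc(Cl)c3)n2)CC1` carries trifluoromethyl in place of methyl on an aromatic carbon, para to a large group: trifluoromethyl in place of methyl on an aromatic carbon. Within the data shown here, none of the measured steps makes this change. Those steps exchange the whole group on the ring nitrogen or the sulfonyl aryl group, and they stay modest in size. No shift beyond the scatter is therefore expected in this assay. The expected change is a 1.2-fold lower number from compound 3 to compound 4 (0.06 log units; within the scatter). For compound 4 the estimated value is 10000 nM, with an expected range of 4000 nM to 28000 nM.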

Compound 4, half-maximal inhibitory concentration: 1540 nM
Estimate against measurement, compound 4: 6.5-fold (0.81 log units) above; the measured number lies below the stated range.
By their numbers in this assay, from the lowest: compound 4; then compound 3; then compound 1. At a limit, above all of these: compound 2.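

Trifluoromethyl in place of methyl, on an aromatic carbon para to a large group, gives a 7.5-fold lower number from compound 3 to compound 4 (0.88 log units; beyond the scatter) in this assay. The earlier steps shown here exchanged the whole group on the ring nitrogen or the sulfonyl aryl group, whereas this one shows that a change at this single position can alone produce a shift beyond the scatter. Nothing measured here gives a cause for this shift. Going by these compounds, what a chlorine, a methoxy group or a nitrile would do at this position stays open. So does whether trifluoromethyl would produce a similar step on the sulfonyl aryl group.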